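Dropping the hydroxymethyl group from compound 2

This account rests on a few compounds, and the source may have more. Where it says the series, first, only, none or still open, it means among the compounds named here.

In a functional assay on MCF7 cells (Homo sapiens) for inhibition, read by CCK-8 assay, with a stated time of 48 h (a lower number here means a stronger inhibitor, a higher number a weaker inhibitor), compound 1 `COc1cc(-c2ccnc3cc(-c4ccc(F)cc4)nn23)cc(OC)c1OC` gives 1280 nM and compound 2 `COc1cc(-c2ccnc3cc(-c4cn(CO)c5ccccc45)nn23)cc(OC)c1OC` gives 19 nM. Compound 2 holds the lower of these two numbers, and the gap lies beyond the scatter. Compound 3 `COc1cc(-c2cc3nccc(-c4c[nH]c5ccccc45)n3n2)cc(OC)c1OC`, which carries hydrogen on the corresponding nitrogen of a rearranged core, reports only a limit, > 10000 nM.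

Compound 4 `COc1cc(-c2ccnc3cc(-c4c[nH]c5ccccc45)nn23)cc(OC)c1OC` has hydrogen in place of hydroxymethyl on an aromatic nitrogen. Among the compounds with values here, no measured pair isolates this change, so the expectation in this assay remains tentative. The expected step of a 1.6-fold higher number from compound 2 to compound 4 (0.20 log units; within the scatter) is a small rise in the number, probably within the scatter. For compound 4, the estimated value is 30 nM, with an expected range of 8 nM to 200 nM.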

Compound 4, half-maximal inhibitory concentration: 85 nM
Compound 4: the middle estimate sits 2.8-fold (0.45 log units) below what was measured; low and high end bracket the measured number.
By their numbers in this assay, from the lowest: compound 2; then compound 4; then compound 1. At a limit, above all of these: compound 3.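

In this assay, replacing hydroxymethyl with hydrogen on the aromatic nitrogen gives a 4.5-fold higher number from compound 2 to compound 4 (0.65 log units; beyond the scatter), so this group has a measurable effect at this position. Without hydroxymethyl, 1H-indol-3-yl in place of 4-fluorophenyl on the shared core still gives a 15-fold lower number from compound 1 to compound 4 (1.18 log units; beyond the scatter), so the indole alone accounts for a large gain. Nothing in the data shown explains either step.

Open, as far as these compounds go, is whether the hydroxyl or the added carbon drives the effect at this nitrogen. A methyl group, a 2-hydroxyethyl chain or an aminomethyl group there would separate these possibilities.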